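The source may report more compounds than this note shows. Statements on the series, on what has been measured and on what is new or still open speak of the compounds shown alone.

Measured in an ADME assay on microsomes from liver (Homo sapiens) for metabolic stability, read by LC-MS, with a stated time of 10 min, tested at 0.5 uM; a higher number here means that more of the compound is left, a lower number that less of the compound is left:
- Compound 1 `c1ccc2c(c1)CN[C@@H](CN(CC[C@@H]1CCCNC1)[C@H]1CCCc3cccnc31)C2`: 75%
- Compound 2 `CC(C)N1CCN(CCCN(C[C@H]2Cc3ccccc3CN2)[C@H]2CCCc3cccnc32)CC1`: 46%
- Compound 3 `c1ccc2c(c1)CN[C@@H](CN(CCN1CCNCC1)[C@H]1CCCc3cccnc31)C2`: 96%

Compound 3 holds the highest number of the three, with a number 21 percentage points higher from compound 1 to compound 3 (beyond the scatter) and a number 50 percentage points higher from compound 2 to compound 3 (beyond the scatter). The move to compound 4 `c1ccc2c(c1)CN[C@@H](CN(CCCN1CCN(C3CC3)CC1)[C@H]1CCCc3cccnc31)C2` is (4-cyclopropylpiperazin-1-yl)methyl in place of piperazin-1-yl on a saturated chain carbon, two bonds along the chain from an amine nitrogen. The closest measured precedent runs the opposite way: (4-isopropylpiperazin-1-yl)methyl gives way to piperazin-1-yl in a number 50 percentage points higher from compound 2 to compound 3 (beyond the scatter), a large step. The same group enters in a number 29 percentage points lower from compound 1 to compound 2 (beyond the scatter), a modest step. Among the compounds with values here, no measured compound carries (4-cyclopropylpiperazin-1-yl)methyl, so the reading from compound 2 is only an analogy. A large downward step in this assay is therefore expected, bringing compound 4 close to compound 2 at 46%. For compound 4 the estimated value is 50%, with an expected range of 30% to 70%. The expected change is a number 46 percentage points lower from compound 3 to compound 4 (beyond the scatter).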

Compound 4, percent of the compound remaining: 21%
Beside the measured number, compound 4's estimate is 29 percentage points above it; the measured number lies below the stated range.
By their numbers in this assay, from the lowest: compound 4; then compound 2; then compound 1; then compound 3.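

In this assay, the step of a number 75 percentage points lower from compound 3 to compound 4 (beyond the scatter) shows that (4-cyclopropylpiperazin-1-yl)methyl at this saturated chain carbon can cost even more than the isopropyl analogue indicated, and the step of a number 54 percentage points lower from compound 1 to compound 4 (beyond the scatter) is also large. The group on the ring amine nitrogen matters by itself: cyclopropyl in place of isopropyl gives the step of a number 25 percentage points lower from compound 2 to compound 4 (beyond the scatter) with the rest of the structure unchanged. Nothing at hand explains these losses.

The compounds shown leave open how much of the loss goes with the longer chain and how much with the group on the ring nitrogen. An unsubstituted piperazine on the longer chain, or a methyl or acetyl on that nitrogen, would help to separate the two.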